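This account rests on a few compounds, and the source may have more. Where it says the series, first, only, none or still open, it means among the compounds named here.

Measured compounds:
- compound 1, `O=C(O)c1cc(-c2cccc(COc3ccc4c(c3)CN(Cc3ccc(C(F)(F)F)cc3)C4=O)c2)ccc1Cl`: 86.7%
- compound 2, `O=C(O)c1cc(-c2cccc(COc3ccc4c(c3)CN(c3ccccc3)C4=O)c2)ccc1Cl`: 86.2%
- compound 3, `O=C(O)c1cc(-c2cccc(COc3ccc4c(c3)CCN(C3CCCC3)C4=O)c2)ccc1Cl`: 66.9%

All three share one core and differ only at the amide-type nitrogen in a ring. In an assay on HEK293 cells for positive allosteric modulation of metabotropic glutamate receptor 2 (Rattus norvegicus), read by thallium flux (a higher number here means a larger maximal response, a lower number a smaller maximal response), compound 2 gives 86.2%, the second highest of the three numbers. Its nearest neighbour is compound 1 at 86.7%, and the two lie within the scatter of each other; compound 3, at 66.9%, sits well below both.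

Compound 4, `O=C(O)c1cc(-c2cccc(COc3ccc4c(c3)CN(C3CC3)C4=O)c2)ccc1Cl`, has not yet been measured. It differs from compound 2 in one place: cyclopropyl in place of phenyl on an amide-type nitrogen in a ring

Going by the values given here, only one measured step changes the same position by itself: a number 0.5 percentage points lower from compound 1 to compound 2 (within the scatter). That step replaced one aromatic ring-bearing group by another and left the maximal response essentially unchanged. Compound 3 carries a non-aromatic ring on the nitrogen and shows a clearly lower number, but its core also differs, so it is not a clean comparison. The expectation is therefore for a modest drop, a number 8.2 percentage points lower from compound 2 to compound 4 (within the scatter), with considerable uncertainty. Compound 4 is estimated to give 78%, between 60% and 95%.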

Compound 4, largest response reached (Emax), in percent of the reference or control that the assay uses: 64.9%
Compound 4: middle estimate off by 13.1 percentage points, on the high side; low and high end bracket the measured number.
By their numbers in this assay, from the lowest: compounds 4 and 3 (each within the scatter of the next); then compounds 2 and 1 (each within the scatter of the next).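

The nitrogen position is not indifferent to the group it carries. In this assay the change to cyclopropyl gives a number 21.3 percentage points lower from compound 2 to compound 4 (beyond the scatter) and also a number 21.8 percentage points lower from compound 1 to compound 4 (beyond the scatter) when it replaces 4-(trifluoromethyl)benzyl, so the earlier match between phenyl and 4-(trifluoromethyl)benzyl did not mean that any group is accepted here. No measurement shown explains why the maximal response falls with cyclopropyl.

Cyclopropyl differs from phenyl both in having no aromatic ring and in having fewer carbons, and these three compounds cannot separate those two changes. A cyclohexyl group on this nitrogen, a six-membered ring of carbon that is not aromatic, would help to tell which change goes with the lower number.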